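Changing the aryl group on the acetylated five-membered core

The source may hold more compounds than are shown below. What is called first, only, known or untested is meant among the compounds shown, and "the series" means these compounds.

Of the compounds shown here, three have so far been tested in a functional assay on PC-3 cells (Homo sapiens) for antiproliferative activity, read by MTT assay, tested at 1 uM; on this read-out higher numbers stand for a stronger effect at the one concentration tested and lower numbers for a weaker effect. Compound 1 `COc1cc(C(=O)N/N=C/c2ccccc2C(F)(F)F)cc(OC)c1OC` gives 45% in this assay, and compound 3 `COc1cc(C(=O)N/N=C/c2cccc(F)c2)cc(OC)c1OC` gives 53.5%. Compound 2 `COc1cc(C2=NN(C(C)=O)C(c3ccccc3C(F)(F)F)O2)cc(OC)c1OC` stands lowest of the three with -11%: its nearest neighbour on the numbers is compound 1, which lies beyond the scatter above it, and compound 3 lies further still, also beyond the scatter. Among the measured compounds shown here, no two of these measured compounds differ in only one place, so there is no single measured step to lean on.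

The next compound, compound 4 `COc1ccc(OC)c(C2OC(c3cc(OC)c(OC)c(OC)c3)=NN2C(C)=O)c1`, differs from compound 2 in one place: 2,5-dimethoxyphenyl in place of 2-(trifluoromethyl)phenyl on a saturated ring carbon. Both keep the acetylated five-membered non-aromatic ring that sets compound 2 apart from the two open-chain compounds. For the measured compounds named here, because compound 2 gives -11% in this assay, and nothing among the measured compounds shows that a different aryl group on that saturated ring carbon restores activity, a modest rise at most is expected, possibly none beyond the scatter. The step from compound 2 to compound 4 is therefore estimated at a number 16 percentage points higher from compound 2 to compound 4 (beyond the scatter). Compound 4 is expected to give about 5%, within a range of -15% to 30%.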

Compound 4, a percentage reported as inhibition, at one concentration (the size of the read-out at that concentration, not a potency): 37.2%
Compound 4: the middle estimate sits 32.2 percentage points below what was measured; measured number outside the range, above it.
By their numbers in this assay, from the lowest: compound 2; then compounds 4, 1 and 3 (each within the scatter of the next, the first and the last beyond it).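

Among the compounds shown here, on the saturated ring carbon of the acetylated five-membered ring, the choice of aryl group makes a large difference in this assay: putting 2,5-dimethoxyphenyl in place of 2-(trifluoromethyl)phenyl gives a number 48.2 percentage points higher from compound 2 to compound 4 (beyond the scatter), the first single-place step in this set. The earlier compounds shown here could not show this, and compound 2 alone left it unclear whether any compound with this acetylated ring could have an effect at the tested concentration; compound 4 gives 37.2% with the same ring, so the ring alone does not rule out a clear effect in this assay. The data shown offer no measured explanation for the size of this step.

Going by these compounds, it remains open whether the step depends on removing the trifluoromethyl group, on adding the two methoxy groups, or on both together, and whether both methoxy groups are needed. An unsubstituted phenyl ring, or a phenyl ring carrying a single methoxy group or an amine, on this same ring carbon would help to separate these possibilities.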